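Methyl on the sulfonyl ring: a second look

The source may hold more compounds than are shown below. What is called first, only, known or untested is meant among the compounds shown, and "the series" means these compounds.

Measured compounds:
compound 1 `O=C1/C(=C/c2cccnc2)CN(S(=O)(=O)c2ccccc2)C/C1=C\c1ccccc1C(F)(F)F` — 5370 nM
compound 2 `Cc1ccc(S(=O)(=O)N2C/C(=C\c3cccnc3)C(=O)/C(=C/c3ccccc3C(F)(F)F)C2)cc1` — 2930 nM
compound 3 `O=C1/C(=C/c2ccncc2)CN(S(=O)(=O)c2ccccc2)C/C1=C\c1ccccc1C(F)(F)F` — 7020 nM

All three were tested in a functional assay on HepG2 cells (Homo sapiens) for cytotoxicity, read by MTT assay, with a stated time of 24 h; a higher number here means a weaker inhibitor, a lower number a stronger inhibitor. Compound 1 and compound 2 differ by methyl in place of hydrogen on an aromatic carbon, and this change gave a 1.8-fold lower number from compound 1 to compound 2 (0.26 log units; within the scatter). Compound 1 and compound 3 differ by pyridin-4-yl in place of pyridin-3-yl on a double-bonded chain carbon bound to a double-bonded ring carbon, which gave a 1.3-fold higher number from compound 1 to compound 3 (0.12 log units; within the scatter). Compound 3 thus holds the highest of the three numbers, yet its gap to compound 1 lies within the scatter; only its gap to compound 2 lies beyond it.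

Compound 4 `Cc1ccc(S(=O)(=O)N2C/C(=C\c3ccncc3)C(=O)/C(=C/c3ccccc3C(F)(F)F)C2)cc1` has not yet been measured in this assay. It differs from compound 3 by methyl in place of hydrogen on an aromatic carbon. Going by the values given here, this is the same change as the one from compound 1 to compound 2, and the description of the place is the same word for word in both cases. The two cores differ by pyridin-4-yl in place of pyridin-3-yl on a double-bonded chain carbon bound to a double-bonded ring carbon.

Among the compounds with values here, the step expected from compound 3 to compound 4 is a 1.8-fold lower number from compound 3 to compound 4 (0.24 log units; within the scatter), set beside a 1.8-fold lower number from compound 1 to compound 2 (0.26 log units; within the scatter) as the only measured example of this change in this assay. It rests on a single pair, and that pair moved within the scatter, so the expectation is loose. Compound 4 is expected to give 4000 nM in this assay, with a likely range from 1800 nM to 9000 nM.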

Compound 4, half-maximal inhibitory concentration: 4640 nM
Estimate against measurement, compound 4: 1.2-fold (0.06 log units) below; low and high end bracket the measured number.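

In this assay, the methyl that turns phenylsulfonyl into (4-methylphenyl)sulfonyl gave a 1.5-fold lower number from compound 3 to compound 4 (0.18 log units; within the scatter), and this step agrees with the earlier one on the other core: the same change on two cores in this assay, a 1.8-fold lower number (0.26 log units; within the scatter) from compound 1 to compound 2 and a 1.5-fold lower number (0.18 log units; within the scatter) from compound 3 to compound 4, 1.2-fold (0.08 log units) apart, within the scatter of two such steps The swap of pyridin-3-yl for pyridin-4-yl, read on the methylated core, gave a 1.6-fold higher number from compound 2 to compound 4 (0.20 log units; within the scatter), and it agrees in the same way with its counterpart: the same change on two cores in this assay, a 1.3-fold higher number (0.12 log units; within the scatter) from compound 1 to compound 3 and a 1.6-fold higher number (0.20 log units; within the scatter) from compound 2 to compound 4, 1.2-fold (0.08 log units) apart, within the scatter of two such steps So among these four compounds each change looks much the same on either core, but every step lies within the scatter, which means the agreement shows only that neither change moved the number measurably on either core, not that a real methyl effect carries across, and two pairs say nothing about cores beyond these.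

The compounds shown leave open whether a larger change at the same place on the sulfonyl ring, such as a methoxy group, a chlorine atom or an amine, would give a step beyond the scatter. They also leave open how the series would respond to a pyridin-2-yl group, or to a nitrile in place of the trifluoromethyl group that all four compounds share.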